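This account rests on a few compounds, and the source may have more. Where it says the series, first, only, none or still open, it means among the compounds named here.

Compound 2 `CC(C)C[C@@H](c1nc2ccc(C(=O)O)cc2n1C)N1C(=O)CN(c2ccc(Oc3ccccc3)cc2)C1=O` is measured in an assay on isolated protein for inhibition of Bile acid receptor (Homo sapiens), read by TR-FRET and LanthaScreen (a higher number here means a weaker inhibitor, a lower number a stronger inhibitor), and gives 43400 nM. That is the higher of the two numbers recorded so far; the other belongs to compound 1 `C[C@@H](c1nc2ccc(C(=O)O)cc2n1C)N1C(=O)CN(c2ccc(Oc3ccccc3)cc2)C1=O`, which in this assay gives 10400 nM. Among the measured compounds shown here, the single step between them, a 4.2-fold higher number from compound 1 to compound 2 (0.62 log units; beyond the scatter), shows that replacing hydrogen on the saturated chain carbon with isopropyl, so that the side chain grows from methyl to isobutyl, weakened inhibition.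

Compound 3 `CC(C)[C@@H](c1nc2ccc(C(=O)O)cc2n1C)N1C(=O)CN(c2ccc(Oc3ccccc3)cc2)C1=O` has not yet been measured. For the measured compounds named here, it differs from compound 2 by isopropyl in place of isobutyl on a saturated chain carbon bound to an amide-type nitrogen in a ring and an aromatic carbon, that is, the branch is pulled in by one carbon, giving a side chain that is larger than the one in compound 1 but smaller than the one in compound 2. Going by the values given here, only the step from compound 1 to compound 2 bears on this change, and it points to the size of this side chain mattering. Since compound 3 sits between the two measured compounds in this respect, the expectation is a number below that of compound 2, with the shift expected to be a 1.7-fold lower number from compound 2 to compound 3 (0.24 log units; within the scatter). In this assay compound 3 is therefore estimated at 25000 nM, with a likely range from 8000 nM to 70000 nM.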

Compound 3, half-maximal inhibitory concentration: 175000 nM
Beside the measured number, compound 3's estimate is 7.0-fold (0.85 log units) below it; measured number outside the range, above it.
By their numbers in this assay, from the lowest: compound 1; then compound 2; then compound 3.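

Removing one carbon from the side chain, so that isobutyl becomes isopropyl, does not move the result back toward compound 1; instead it gives a 4.0-fold higher number from compound 2 to compound 3 (0.61 log units; beyond the scatter), making isopropyl the weakest of the three groups at this position in this assay. Compared directly with methyl, isopropyl gives a 17-fold higher number from compound 1 to compound 3 (1.23 log units; beyond the scatter), the largest step seen so far, so inhibition on this saturated chain carbon does not follow carbon count alone: isopropyl, with 3 carbons, has a higher number than isobutyl, with 4, and compound 2 goes against any simple rule that a larger group gives a weaker inhibitor. No independent measurement here accounts for this order, so the result stands as an observation without an explanation.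

The compounds shown leave open how an ethyl group or a straight propyl chain would compare with these three groups, and so whether the high number of compound 3 goes with isopropyl in particular. They also leave open whether a cyclopropyl ring or a tert-butyl group at this carbon would fall closer to compound 1 or to compound 3.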